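A few compounds are considered here, and "the series" means these few. Any claim that something is new, unique, unknown or untested is made for them only; others in the source may bear on it.

In a functional assay on Fem-X cells (Homo sapiens) for cytotoxicity, read by MTT assay, with a stated time of 72 h (on this read-out higher numbers stand for weaker inhibition and lower numbers for stronger inhibition), compound 1 `Cc1ccc(-c2ccnc(Nc3ccc(F)cc3)c2)cc1` gives 79000 nM and compound 2 `COc1ccc(Nc2cc(-c3cccc(C(F)(F)F)c3)ccn2)cc1` gives 68000 nM as its number, so the two stand within the usual scatter of each other and cannot be ranked. Compound 3 `CCc1ccc(Nc2cc(-c3cccc(C(F)(F)F)c3)ccn2)cc1` differs from compound 2 at a single place, with ethyl in place of methoxy on an aromatic carbon and the rest unchanged. Within the data shown here, no measured pair shows this swap, so the only guide is compound 2 at 68000 nM and no step beyond the scatter is expected in either direction. The expected step of a 1.1-fold lower number from compound 2 to compound 3 (0.05 log units; within the scatter) is therefore small. Compound 3 is estimated at 60000 nM (range 28000 nM to 120000 nM).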

Compound 3, half-maximal inhibitory concentration: > 200000 nM
Compound 3: only a limit was reported; the forecaster's own chance of this, stated with the estimate: 15%; middle value at least 3.3-fold (0.52 log units) away from the limit.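

Replacing methoxy with ethyl on this aromatic carbon, para to a large group, is not a neutral swap in this assay: the change gives an at least 2.9-fold higher number from compound 2 to compound 3 (0.46 log units; beyond the scatter). Both groups have 2 heavy atoms, yet ethyl has no hydrogen-bond acceptor, so a small change at this position can move the read-out beyond the scatter. Compound 3 has only a limit of the assay, not a number: the limit of > 200000 nM in this assay, at which 1 of the 3 values shown sits.

From the compounds shown here alone, only these two groups can be compared here, so the role of the oxygen stays open. A hydroxyl group, an amine or a longer chain at this position could help to separate the effect of the oxygen from that of the group's size.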